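The source may hold more compounds than are shown below. What is called first, only, known or untested is meant among the compounds shown, and "the series" means these compounds.

Compound 1 `CC(C)(O)C#Cc1ccc(NC(=O)CSc2nnnn2-c2ccc(C3CC3)cc2Cl)c(Cl)c1` gives 1.4 h
Compound 2 `CC(C)(C#Cc1ccc(NC(=O)CSc2nnnn2-c2ccc(C3CC3)cc2Cl)c(Cl)c1)NCC(=O)O` gives 1.17 h

Within the data shown here, in an in vitro ADME assay on microsomes from liver (Rattus norvegicus) for metabolic stability, tested at 2 uM (a lower number here means that the compound disappears faster, a higher number that the compound lasts longer), compound 1 gives 1.4 h and stands level with compound 2, the only other compound measured. Compound 3 `O=C(O)CC#Cc1ccc(NC(=O)CSc2nnnn2-c2ccc(C3CC3)cc2Cl)c(Cl)c1` keeps the core of compound 1 and changes one group (carboxymethyl in place of 1-hydroxy-1-methylethyl on a triple-bonded carbon): carboxymethyl in place of 1-hydroxy-1-methylethyl on a triple-bonded carbon. Among the measured compounds shown here, the one measured step that bears on this (a 1.2-fold lower number from compound 1 to compound 2 (0.08 log units; within the scatter)) also brings in a carboxymethyl group, but it keeps the rest of the 1-hydroxy-1-methylethyl carbons, so the evidence is thin. No change beyond the scatter is therefore expected, only a small estimated step (a 1.1-fold lower number from compound 1 to compound 3 (0.03 log units; within the scatter)). Compound 3 is expected at 1.3 h (estimated range 0.7 h to 2.6 h).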

Compound 3, half-life: 0.317 h
For compound 3 the middle estimate is 4.1-fold (0.61 log units) above the measured one; measured number below the stated range.
By their numbers in this assay, from the lowest: compound 3; then compounds 2 and 1 (each within the scatter of the next).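

In this assay the group on this triple-bonded carbon clearly matters: swapping 1-hydroxy-1-methylethyl for carboxymethyl gives a 4.4-fold lower number from compound 1 to compound 3 (0.65 log units; beyond the scatter), a change the earlier pair never showed. Compound 2 also carries a carboxylic acid, yet replacing its whole group with carboxymethyl gives a 3.7-fold lower number from compound 2 to compound 3 (0.57 log units; beyond the scatter), so having an acid in the group does not alone set the number. Nothing available explains this loss. Still open, from the compounds shown here alone, is how an amine, or a longer chain ending in the acid, would fare on this same carbon.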